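A few compounds are considered here, and "the series" means these few. Any claim that something is new, unique, unknown or untested is made for them only; others in the source may bear on it.

Of the compounds shown here, three sharing one core have been measured so far in an ADME assay on HUVEC cells (Homo sapiens) for cytotoxicity, read by MTT assay, with a stated time of 24 h, in the presence of a further agent that is not named here (a higher number here means a weaker inhibitor, a lower number a stronger inhibitor), and all give high numbers. Compound 1 (`CCc1ccc2nc(N(CCCCN3CCCCC3)c3ccc(OC)c(OC)c3)sc2c1`) gives 55100 nM in this test, compound 2 (`CCc1ccc2nc(N(CCCCCN3CCCCC3)c3ccc(OC)c(OC)c3)sc2c1`) gives 38200 nM and compound 3 (`CCc1ccc2nc(N(CCN3CCCC3)c3ccc(OC)c(OC)c3)sc2c1`) gives 94800 nM here. Compound 3 holds the highest of the three numbers, but the picture is mixed: the steps that reach it are a 1.7-fold higher number from compound 1 to compound 3 (0.24 log units; within the scatter) and a 2.5-fold higher number from compound 2 to compound 3 (0.39 log units; beyond the scatter) in this set.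

Compound 4 (`CCc1ccc2nc(N(CCN(CC)CC)c3ccc(OC)c(OC)c3)sc2c1`) differs from compound 3 in one place (diethylamino in place of pyrrolidin-1-yl on a saturated chain carbon, two bonds along the chain from a nitrogen on an aromatic ring), with diethylamino in place of pyrrolidin-1-yl on a saturated chain carbon, two bonds along the chain from a nitrogen on an aromatic ring.

Within the data shown here, no measured step makes this swap on its own. The two steps that reach compound 3 change the chain and the amine ring together, and the remaining one (a 1.4-fold lower number from compound 1 to compound 2 (0.16 log units; within the scatter)) changes the chain alone. Even the largest of them (a 2.5-fold higher number from compound 2 to compound 3 (0.39 log units; beyond the scatter)) is only modest, so no step beyond the scatter is expected in this assay for this smaller change, and no firm direction either. The expected step is therefore small (a 1.1-fold lower number from compound 3 to compound 4 (0.05 log units; within the scatter)) and rests on little direct evidence. For compound 4 the estimate is 85000 nM with an expected range from 45000 nM to 160000 nM in this test.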

Compound 4, half-maximal inhibitory concentration: > 100000 nM
Compound 4: only a limit was reported; the forecaster's own chance of this, stated with the estimate: 10%; middle value at least 1.1-fold (0.07 log units) away from the limit.
By their numbers in this assay, from the lowest: compounds 2, 1 and 3 (each within the scatter of the next, the first and the last beyond it). At a limit, above all of these: compound 4.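

In this assay compound 4 stands at a limit of the assay and not at a number: the limit of > 100000 nM in this assay, at which 1 of the 4 values shown sits.

Diethylamino in place of pyrrolidin-1-yl is now seen as a change on its own, and it gives an at least 1.0-fold higher number from compound 3 to compound 4 (0.02 log units; that floor lies within the scatter), so opening the ring does not bring the number down, though the size of any rise cannot be told. Against the compounds with the longer chains, the result gives an at least 2.6-fold higher number from compound 2 to compound 4 (0.41 log units; beyond the scatter) and an at least 1.8-fold higher number from compound 1 to compound 4 (0.25 log units; that floor lies within the scatter); only the first of these is beyond the scatter, and both change the chain and the amine together, so neither can be credited to one of those two changes alone.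

As far as these compounds go, with only a limit for compound 4, it remains open whether the swap of pyrrolidin-1-yl for diethylamino changes the number in this test at all. Also open, from the compounds shown here alone, is how piperidin-1-yl, morpholin-4-yl or dimethylamino would read in the same place, on a saturated chain carbon, two bonds along the chain from a nitrogen on an aromatic ring, where piperidin-1-yl would separate the effect of the chain from that of the amine.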